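A few compounds are considered here, and "the series" means these few. Any claim that something is new, unique, unknown or untested is made for them only; others in the source may bear on it.

In an assay on cells (Epithelial cell) with Cystic fibrosis transmembrane conductance regulator variant F508del (Homo sapiens) as the target, read by fluorescence, with a stated time of 20 h (on this read-out higher numbers stand for weaker inhibition and lower numbers for stronger inhibition), compound 3 `COc1ccc(Cl)cc1Nc1nc2c(s1)CCCCc1nc(NC(=O)C3CC3)sc1-2` gives 4500 nM, which places it second highest of the three numbers measured, close to compound 2 `COc1ccc(Cl)cc1Nc1nc2c(s1)CCCCc1nc(NC(=O)C(C)(C)C)sc1-2`, which gives 4100 nM, and furthest from compound 1 `COc1ccc(Cl)cc1Nc1nc2c(s1)CCCCc1nc(N)sc1-2`, which gives 9200 nM. The step from compound 3 to compound 4 `COc1ccc(Cl)cc1Nc1nc2c(s1)CCCCc1nc(NC(=O)C(C)C)sc1-2` is isopropyl in place of cyclopropyl on a carbonyl carbon. The measured steps that bear on it are the two that put a carbonyl-bearing group on the nitrogen on the aromatic ring, a 2.2-fold lower number from compound 1 to compound 2 (0.35 log units; beyond the scatter) and a 2.0-fold lower number from compound 1 to compound 3 (0.31 log units; beyond the scatter), and above all the exchange of one such group for another, a 1.1-fold higher number from compound 2 to compound 3 (0.04 log units; within the scatter). Since swapping tert-butyl for cyclopropyl on the carbonyl carbon left the number within the scatter, a further swap of cyclopropyl for isopropyl at the same place is expected to give no step beyond the scatter in this assay, so the expected step is no change at the digits printed from compound 3 to compound 4 (within the scatter). Compound 4 is therefore estimated at 4500 nM in this assay, with a range from 2500 nM to 8000 nM.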

Compound 4, half-maximal inhibitory concentration: 8700 nM
Beside the measured number, compound 4's estimate is 1.9-fold (0.29 log units) below it; measured number above the stated range.
By their numbers in this assay, from the lowest: compounds 2, 3, 4 and 1 (each within the scatter of the next, the first and the last beyond it).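

In this assay the group on the carbonyl carbon now separates two amides, which the earlier amides did not do, with hydrogen in place of methyl on the saturated chain carbon giving a modest step (a 2.1-fold higher number from compound 2 to compound 4 (0.33 log units; beyond the scatter)). Placing a carbonyl-bearing group on the nitrogen no longer gives a step beyond the scatter in every case, as isopropylcarbonyl shows (a 1.1-fold lower number from compound 1 to compound 4 (0.02 log units; within the scatter)), while the exchange of cyclopropyl for isopropyl itself stays within the scatter (a 1.9-fold higher number from compound 3 to compound 4 (0.29 log units; within the scatter)), so the tert-butyl amide compound 2 is the only one of these amides that the isopropyl amide compound 4 can be told apart from. Nothing available here accounts for these differences.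

The compounds shown leave open how a longer chain or an amine on the carbonyl carbon would read. They also leave open whether a carboxylic acid at that place would read differently from these amides.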